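The source may report more compounds than this note shows. Statements on the series, on what has been measured and on what is new or still open speak of the compounds shown alone.

Compound 1 `CC(C)C(Cc1ncc[nH]1)c1ccc(-c2ccc3cccc(F)c3c2)[nH]c1=O`: 76 nM
Compound 2 `CC(C)C(Cc1nnc[nH]1)c1ccc(-c2ccc3cccc(F)c3c2)[nH]c1=O`: 17 nM
Compound 3 `CC(C)C(c1ccc(-c2ccc3cccc(F)c3c2)[nH]c1=O)N1CCCCC1=O`: 40 nM

All three share one core and were tested in a functional assay on CHO cells for antagonist activity at prostaglandin E2 receptor EP3 subtype (Homo sapiens), read by cAMP accumulation; on this read-out lower numbers stand for stronger inhibition and higher numbers for weaker inhibition. Compound 3 stands second highest of the three numbers: its gap to compound 1 is within the scatter (a 1.9-fold lower number from compound 1 to compound 3 (0.28 log units; within the scatter)), while the gap to compound 2 is beyond it (a 2.4-fold higher number from compound 2 to compound 3 (0.37 log units; beyond the scatter)). Compound 4 `Cc1nc(C(c2ccc(-c3ccc4cccc(F)c4c3)[nH]c2=O)C(C)C)[nH]c1C` differs from compound 3 by 4,5-dimethyl-1H-imidazol-2-yl in place of 2-oxopiperidin-1-yl on a saturated chain carbon bound to an aromatic carbon and a saturated chain carbon. Among the compounds with values here, the only measured step that bears on this is a 1.9-fold lower number from compound 1 to compound 3 (0.28 log units; within the scatter), where a (1H-imidazol-2-yl)methyl group stood in place of the same 2-oxopiperidin-1-yl and the numbers hardly moved. Within the data shown here, compound 4 carries its imidazole directly on the chain carbon and with two methyls, a change no measured step covers. The expected step is therefore a 1.5-fold higher number from compound 3 to compound 4 (0.18 log units; within the scatter), small and probably within the scatter. Compound 4 is estimated at 60 nM, between 20 nM and 180 nM.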

Compound 4, half-maximal inhibitory concentration: 50 nM
Estimate against measurement, compound 4: 1.2-fold (0.08 log units) above; the measured number falls inside the stated range.
By their numbers in this assay, from the lowest: compound 2; then compounds 3, 4 and 1 (each within the scatter of the next).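

In this assay, this saturated chain carbon accepts a five-membered aromatic ring with a hydrogen-bond donor about as well as a six-membered non-aromatic ring without one: a 1.3-fold higher number from compound 3 to compound 4 (0.10 log units; within the scatter). The (1H-imidazol-2-yl)methyl group gives a similar result, a 1.5-fold lower number from compound 1 to compound 4 (0.18 log units; within the scatter), while the (4H-1,2,4-triazol-3-yl)methyl group keeps a real advantage, a 2.9-fold higher number from compound 2 to compound 4 (0.47 log units; beyond the scatter). No measurement available here explains these results. The compounds shown do not separate the effect of the two methyl groups from that of the ring itself. From the compounds shown here alone, how an unsubstituted 1H-imidazol-2-yl, an amine or a carboxylic acid would behave on this carbon remains open.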